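Adding Bromine to a Benzyl Ring on a Weak Inhibitor

The source may hold more compounds than are shown below. What is called first, only, known or untested is meant among the compounds shown, and "the series" means these compounds.

Compound 2 `CCOC(=O)c1oc2ccc(N(Cc3ccccc3)S(=O)(=O)c3ccccc3)cc2c1C` was tested in a functional assay on HCT-116 cells (Homo sapiens) for inhibition, read by MTT assay, with a stated time of 72 h; a lower number here means a stronger inhibitor, a higher number a weaker inhibitor. In this assay compound 2 reaches only the limit of the measurement, > 40000 nM. Compound 1 `CCOC(=O)c1oc2ccc(N(Cc3ccccc3)S(=O)(=O)c3ccccc3Br)cc2c1C` differs from compound 2 by bromo in place of hydrogen on an aromatic carbon. For compound 1 this assay again gives only a limit, > 40000 nM. The step that the two limits leave unreadable from compound 2 to compound 1 therefore has no readable size, a consequence of the limit of > 40000 nM in this assay, at which 2 of the 3 values shown sit. Compound 3 `Cc1c(C(=O)O)oc2ccc(N(Cc3ccccc3)S(=O)(=O)c3ccc(Br)cc3)cc12` carries a different core; how its core differs from that of compound 2 is not broken down here. In this assay, going by the values given here, compound 3 gives 20000 nM, the one number among the three. Compound 4 `Cc1c(C(=O)O)oc2ccc(N(Cc3ccc(Br)cc3)S(=O)(=O)c3ccc(Br)cc3)cc12` has not been measured and differs from compound 3 by bromo in place of hydrogen on an aromatic carbon. Among the compounds with values here, this is the same kind of change as the one from compound 2 to compound 1, but not the same: in the earlier pair the bromo sits ortho to a large group, in the new pair para to a large group. The expected step is a 1.3-fold lower number from compound 3 to compound 4 (0.12 log units; within the scatter), small because the measured step that the two limits leave unreadable from compound 2 to compound 1 offers no readable size to build on. The estimate for compound 4 is 15000 nM, with a range from 5000 nM to 40000 nM.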

Compound 4, half-maximal inhibitory concentration: > 40000 nM
Compound 4 was reported as a limit; the forecaster's own chance of this, stated with the estimate: 30%; middle value at least 2.6-fold (0.42 log units) from the limit.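

In this assay the new step is an at least 2.0-fold higher number from compound 3 to compound 4 (0.30 log units; that floor lies within the scatter), so placing bromo on the benzyl group of compound 3 gives no stronger inhibitor, though the floor of that step alone does not establish a real loss. The step from compound 2 to compound 1 cannot be read, so the data do not show whether this change acts alike on the two cores, and the bromo also sits in a different place in that earlier pair. The true size of the new step stays unknown because compound 4 gives only a limit, not a number: the limit of > 40000 nM in this assay, at which 3 of the 4 values shown sit.

As far as these compounds go, it remains open whether an amine, a hydroxyl group or a fluoro group in the same place on the benzyl group of compound 3 would give a lower number than compound 3 or a higher one. Also open, from the compounds shown here alone, is whether bromo at another place on that ring would leave a value that can be read.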